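The source may report more compounds than this note shows. Statements on the series, on what has been measured and on what is new or still open speak of the compounds shown alone.

In a functional assay on MCF7 cells (Homo sapiens) for cytotoxicity, read by MTT assay, with a stated time of 48 h (a lower number here means a stronger inhibitor, a higher number a weaker inhibitor), compound 3 (`C/C(=N/NC(=S)Nc1ccccc1F)c1ccccn1`) gives 0.39 nM. That is level with compound 2 (`CC(=NNC(=S)Nc1ccccc1F)c1ccccn1`) at 0.39 nM, while compound 1 (`C/C(=N\NC(=S)Nc1ccccc1I)c1ccccn1`) stands clearly higher at 4.1 nM. The next compound to consider is compound 4 (`C/C(=N/NC(=S)Nc1ccccc1)c1ccccn1`). It differs from compound 3 by a single swap, (hydrogen in place of fluoro on an aromatic carbon), with hydrogen in place of fluoro on an aromatic carbon.

The measured data offer little direct guidance on this swap. For the measured compounds named here, the only measured step shows no change at the digits printed from compound 2 to compound 3 (within the scatter). It rests on (the fact that one of compounds 2 and 3 is drawn with a defined configuration and the other without, at the place where they differ), and the fluoro group stays in place, so it does not test the removal of fluoro. Going by the values given here, no measured step isolates this swap, so the size of the change has to be judged loosely from the spread of the values. That spread runs from compound 3 at 0.39 nM to compound 1 at 4.1 nM, and it suggests that a large jump is not the likeliest outcome. A small rise in the number, meaning a somewhat weaker inhibitor and lying close to the usual scatter, is expected for a 2.1-fold higher number from compound 3 to compound 4 (0.31 log units; beyond the scatter). The estimated value for compound 4 is 0.8 nM, with an expected range of 0.15 nM to 4 nM.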

Compound 4, half-maximal inhibitory concentration: 0.18 nM
Compound 4: middle estimate off by 4.4-fold (0.65 log units), on the high side, and the stated range covers the measured number.
By their numbers in this assay, from the lowest: compound 4; then compounds 2 and 3 (each within the scatter of the next); then compound 1.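

In this assay, putting hydrogen in place of fluoro on this aromatic carbon, ortho to a large group, gives a 2.2-fold lower number from compound 3 to compound 4 (0.34 log units; beyond the scatter), a modest step but one beyond the usual scatter. For the compounds shown here, this shows that the low number does not depend on keeping the fluoro group at this position, and that the unsubstituted ring does slightly better here, which the earlier compounds could not show, as their one measured step left the fluoro group in place and concerned only how a double bond is drawn. Going by these compounds alone, the one piece of supporting information concerns that drawing of the double bond, so it has no bearing on the swap of fluoro for hydrogen and offers no explanation for this result.

Still open, going by these compounds, is how other groups at this position would behave: a methyl, a methoxy, an amine or a carboxylic acid on this aromatic carbon would show whether hydrogen is the best choice here or merely one of several that work. Compound 1 carries iodo at this position, but its double bond is also drawn differently from that of compound 4, so the effect of iodo cannot be separated from that second difference.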